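Replacing the group on a carbonyl carbon in compound 3

The source may hold more compounds than are shown below. What is called first, only, known or untested is meant among the compounds shown, and "the series" means these compounds.

- compound 1 `COc1cc(Nc2ncnc3c(NC(=O)Nc4cc(C)cc(C)c4)cccc23)cc(OC)c1`: 10100 nM
- compound 2 `COc1cc(Nc2ncnc3c(NC(=O)Nc4ccc(C(F)(F)F)cc4)cccc23)cc(OC)c1`: 3920 nM
- compound 3 `COc1cc(Nc2ncnc3c(NC(=O)c4ccc(CN(C)C)cc4)cccc23)cc(OC)c1`: 4370 nM

In a functional assay on RT-112 cells (Homo sapiens) for antiproliferative activity, read by MTT assay, with a stated time of 72 h (on this read-out lower numbers stand for stronger inhibition of growth and higher numbers for weaker inhibition of growth), compound 3 gives 4370 nM. The nearest measured neighbour is reached by a 1.1-fold higher number from compound 2 to compound 3 (0.05 log units; within the scatter), and the furthest by a 2.3-fold lower number from compound 1 to compound 3 (0.36 log units; beyond the scatter).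

The next compound is compound 4 `COc1cc(Nc2ncnc3c(NC(=O)c4cc(=O)c5ccccc5o4)cccc23)cc(OC)c1`, and the change is a group of 11 heavy atoms (9 carbon, 2 oxygen; one six-membered aromatic ring of carbon only, one six-membered aromatic ring with 1 hetero atom) in place of a group of 10 heavy atoms (9 carbon, 1 nitrogen; one six-membered aromatic ring of carbon only), on a carbonyl carbon.

The two steps above bear most directly on this change, as both replace the group on a carbonyl carbon. Within the data shown here, the only other measured step, a 2.6-fold lower number from compound 1 to compound 2 (0.41 log units; beyond the scatter), is a change on an amide-type nitrogen and is also modest. Among the measured compounds shown here, no measured compound carries a six-membered aromatic ring with 1 hetero atom, so the series offers no direct precedent for the entering group. As far as these compounds go, with steps this small at the same place, no change beyond the scatter is expected in this assay, and the direction remains open.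

An estimated 1.1-fold higher number from compound 3 to compound 4 (0.06 log units; within the scatter) is therefore expected. Compound 4 is expected at 5000 nM, with an estimated range of 1800 nM to 14000 nM.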

Compound 4, concentration for 50% growth inhibition: > 20000 nM
Compound 4: only a limit was reported (the forecaster's own chance of this, stated with the estimate: 10%); middle value at least 4.0-fold (0.60 log units) from the limit.
By their numbers in this assay, from the lowest: compounds 2 and 3 (each within the scatter of the next); then compound 1. At a limit, above all of these: compound 4.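

Compound 4 stands only as a limit of the assay: the limit of > 20000 nM in this assay, at which 1 of the 4 values shown sits. The earlier change on a carbonyl carbon left the number within the scatter (a 1.1-fold higher number from compound 2 to compound 3 (0.05 log units; within the scatter)), whereas the group with a six-membered aromatic ring with 1 hetero atom gives an at least 4.5-fold higher number from compound 3 to compound 4 (0.66 log units; beyond the scatter) and an at least 5.1-fold higher number from compound 2 to compound 4 (0.70 log units; beyond the scatter), so this place does not accept every ring-bearing group without a loss of growth inhibition. The remaining step is an at least 1.9-fold higher number from compound 1 to compound 4 (0.29 log units; that floor lies within the scatter), so it does not show a change beyond the scatter.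

As far as these compounds go, how far the true number of compound 4 lies past the limit stays open. Also open, from the compounds shown here alone, is whether the entering ring system, its two oxygens or the missing dimethylamino nitrogen carries the loss; a plain phenyl, or a phenyl bearing a morpholine or a carboxylic acid, on the same carbonyl carbon would separate these.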